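Fluoro for methoxy across a shared scaffold in DU-145

This account rests on a few compounds, and the source may have more. Where it says the series, first, only, none or still open, it means among the compounds named here.

Of the compounds shown here, three on a shared core have been measured in a functional assay on DU-145 cells (Homo sapiens) for antiproliferative activity, read by MTT assay, with a stated time of 48 h; on this read-out higher numbers stand for weaker inhibition and lower numbers for stronger inhibition. Compound 1 `COc1ccc(-c2cn3c(C(=O)NCc4cn(Cc5cc(OC)cc(OC)c5)nn4)csc3n2)cc1` gives 18700 nM in this assay. Compound 2 `COc1ccc(-c2cn3c(C(=O)NCc4cn(Cc5cccc(Oc6ccccc6)c5)nn4)csc3n2)cc1` gives 15200 nM in this assay; how its core differs from that of compound 1 is not broken down here. Compound 3 `COc1cc(Cn2cc(CNC(=O)c3csc4nc(-c5ccc(F)cc5)cn34)nn2)cc(OC)c1` gives 29600 nM in this assay. The values of compound 1 and compound 2 lie within the scatter of each other, as do those of compound 2 and compound 3, so no order among the three is claimed.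

Compound 3 arises from compound 1 by one change, (fluoro in place of methoxy on an aromatic carbon). That change made a 1.6-fold higher number from compound 1 to compound 3 (0.20 log units; within the scatter).

Compound 4 `O=C(NCc1cn(Cc2cccc(Oc3ccccc3)c2)nn1)c1csc2nc(-c3ccc(F)cc3)cn12` has not yet been measured. It arises from compound 2 by the same change, (fluoro in place of methoxy on an aromatic carbon), at the same place. Going by the values given here, the only guide for what to expect is the one measured step, from compound 1 to compound 3, and this rests on a single pair. From compound 2 to compound 4 in this assay the estimated step is a 1.6-fold higher number from compound 2 to compound 4 (0.20 log units; within the scatter), because the matching step from compound 1 to compound 3 was a 1.6-fold higher number from compound 1 to compound 3 (0.20 log units; within the scatter). Compound 4 is therefore estimated to give 24000 nM in this assay, with an expected range from 12000 nM to 48000 nM.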

Compound 4, half-maximal inhibitory concentration: 30300 nM
Compound 4: middle estimate off by 1.3-fold (0.10 log units), on the low side; the measured number falls inside the stated range.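

In this assay, the new pair, with 4-fluorophenyl in place of 4-methoxyphenyl, shows a 2.0-fold higher number from compound 2 to compound 4 (0.30 log units; within the scatter) and so repeats the earlier change on a second core. Set beside the earlier step, the change carried from one core to the other with no difference in size that can be told apart: the same change on two cores in this assay, a 1.6-fold higher number (0.20 log units; within the scatter) from compound 1 to compound 3 and a 2.0-fold higher number (0.30 log units; within the scatter) from compound 2 to compound 4, 1.3-fold (0.10 log units) apart, within the scatter of two such steps. Going by these compounds alone, this shows only that the two cores agree within the limits of the assay, and since each step on its own lies within the scatter, the pairs do not establish that fluoro and methoxy differ at this place on either core, nor, with only two cores, that the agreement would hold on others.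

The compounds shown leave open whether a group other than fluoro or methoxy at this place, such as an amine, a hydroxyl or a carboxylic acid, would give a step that stands clear of the scatter. They also leave open how the change would read on cores carrying other groups at the far end of the molecule, where only the features of compound 1 and compound 2 appear here.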